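This account rests on a few compounds, and the source may have more. Where it says the series, first, only, none or still open, it means among the compounds named here.

In a functional assay on cells (Tumor Cell line, Homo sapiens) for cytotoxicity (a lower number here means a stronger inhibitor, a higher number a weaker inhibitor), compound 1 (`CN(C)Cc1cc(C(=O)/C=C/c2cccc(Cl)c2)cc(CN(C)C)c1O`) gives 4680 nM and compound 2 (`CN(C)Cc1cc(C(=O)/C=C/c2ccc(Cl)cc2Cl)cc(CN(C)C)c1O`) gives 3090 nM, two values within the scatter of each other. Compound 3 (`CN(C)Cc1cc(C(=O)/C=C/c2ccc(F)cc2)cc(CN(C)C)c1O`) is reached from compound 1 by 4-fluorophenyl in place of 3-chlorophenyl on a double-bonded chain carbon bound to a double-bonded chain carbon. Going by the values given here, the only measured step at this place is a 1.5-fold lower number from compound 1 to compound 2 (0.18 log units; within the scatter), and the 4-fluorophenyl group itself has no measurement yet. Among the compounds with values here, with only that small step to go on, no change beyond the scatter is expected in this assay. The expected step is a 1.2-fold lower number from compound 1 to compound 3 (0.09 log units; within the scatter). Compound 3 is estimated at 3800 nM, with an expected range of 1800 nM to 8000 nM.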

Compound 3, half-maximal inhibitory concentration: 20000 nM
Estimate against measurement, compound 3: 5.3-fold (0.72 log units) below; measured number outside the range, above it.
By their numbers in this assay, from the lowest: compounds 2 and 1 (each within the scatter of the next); then compound 3.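

In this assay, this position on a double-bonded chain carbon bound to a double-bonded chain carbon proves sensitive to the change: 4-fluorophenyl gives a 4.3-fold higher number from compound 1 to compound 3 (0.63 log units; beyond the scatter) and a 6.5-fold higher number from compound 2 to compound 3 (0.81 log units; beyond the scatter), whereas the step between the two chlorine-bearing groups stayed within the scatter. Nothing at hand bears on what lies behind this rise.

Open, as far as these compounds go, is whether the rise goes with fluorine in place of chlorine or with where the halogen sits, as both differ here. A 4-chlorophenyl group would separate the two, and a ring carrying an amine would test a non-halogen substituent.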